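Two 7-Deazapurine Nucleosides Compared Across a Heteroaryl Swap

A few compounds are considered here, and "the series" means these few. Any claim that something is new, unique, unknown or untested is made for them only; others in the source may bear on it.

Compound 2 `COc1nc(N)nc2c1c(-c1ccoc1)cn2[C@@H]1O[C@H](CO)[C@@H](O)[C@H]1O` and compound 1 `COc1nc(N)nc2c1c(-c1cccs1)cn2[C@@H]1O[C@H](CO)[C@@H](O)[C@H]1O` share one core, while compound 3 `CSc1ncnc2c1c(-c1ccoc1)cn2[C@@H]1O[C@H](CO)[C@@H](O)[C@H]1O` carries a different core; the difference between the two cores is not broken down here. In a functional assay on HCT-116 cells (Homo sapiens), read by MTT assay, with a stated time of 72 h (on this read-out higher numbers stand for weaker inhibition and lower numbers for stronger inhibition), compound 2 gives only a limit of the assay, > 20000 nM. Compound 1 likewise gives only a limit in this assay, > 20000 nM. Their step, a step that the two limits leave unreadable from compound 2 to compound 1, is therefore (thiophen-2-yl in place of furan-3-yl on an aromatic carbon). Among the compounds with values here, compound 3 gives 40 nM in this assay, the only number among the three, the other two sitting at the limit of > 20000 nM in this assay, at which 2 of the 3 values shown sit. Compound 4 `CSc1ncnc2c1c(-c1cccs1)cn2[C@@H]1O[C@H](CO)[C@@H](O)[C@H]1O` makes the same kind of change on the core of compound 3: thiophen-2-yl in place of furan-3-yl on an aromatic carbon. Because compound 3 gives 40 nM and the earlier step is unreadable, compound 4 is expected to stay close, a step of a 1.3-fold higher number from compound 3 to compound 4 (0.10 log units; within the scatter). Compound 4 is thus estimated at 50 nM, between 15 nM and 200 nM.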

Compound 4, half-maximal inhibitory concentration: > 20000 nM
Compound 4 ended at the assay's limit (the forecaster's own chance of this, stated with the estimate: 5%); middle value at least 400-fold (2.60 log units) from the limit.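

In this assay, thiophen-2-yl in place of furan-3-yl on an aromatic carbon gives an at least 500-fold higher number from compound 3 to compound 4 (2.69 log units; beyond the scatter), so on the core of compound 3 this change is far from neutral. Compound 4 itself gives only a limit of the assay, > 20000 nM. The same change cannot be read on the core of compound 1 and compound 2, so the result does not show whether its effect carries from one core to the other: the limit of > 20000 nM in this assay, at which 3 of the 4 values shown sit.

The compounds shown leave open whether the exchange of oxygen for sulfur or the shift in the point of attachment carries the step. Thiophen-3-yl or furan-2-yl on the core of compound 3 would separate the two.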